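The compounds below may be only part of what the source reports. "The series", "measured", "known", "first", "only" and "open" are said of these compounds alone.

Working notes on the series, read in a functional assay on MCF7 cells (Homo sapiens) for inhibition, read by MTT assay, with a stated time of 72 h; a lower number here means a stronger inhibitor, a higher number a weaker inhibitor. Among the compounds with values here, compound 1 `Cc1cc2occ(-c3nc(-c4ccccc4)c(-c4ccccc4)n3-c3ccc([N+](=O)[O-])cc3)c(=O)c2cc1Cl` gives 6250 nM, and compound 2 `Cc1cc2occ(-c3nc(-c4ccccc4)c(-c4ccccc4)n3-c3cccc(Cl)c3)c(=O)c2cc1Cl` gives 6250 nM, so compound 2 stands level with compound 1, its only measured neighbour.

Compound 3 `COc1cccc(-n2c(-c3coc4cc(C)c(Cl)cc4c3=O)nc(-c3ccccc3)c2-c2ccccc2)c1` follows from compound 2 by one exchange, methoxy in place of chloro on an aromatic carbon, meta to a large group, which also reads as 3-chlorophenyl to 3-methoxyphenyl.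

Within the data shown here, one measured step bears on this, no change at the digits printed from compound 1 to compound 2 (within the scatter), where 3-chlorophenyl took the place of 4-nitrophenyl on an aromatic nitrogen. Among the measured compounds shown here, that step altered the same phenyl group and left this assay unmoved, but a single step makes no pattern, and no measured compound carries a methoxy group. No step beyond the scatter is therefore expected in this assay, and no direction is favoured.

The expected step is no change at the digits printed from compound 2 to compound 3 (within the scatter). Compound 3 is estimated at 6250 nM, with an expected range of 3000 nM to 12500 nM.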

Compound 3, half-maximal inhibitory concentration: 25000 nM
Compound 3: the middle estimate sits 4.0-fold (0.60 log units) below what was measured; the whole stated range lies below it.
By their numbers in this assay, from the lowest: compounds 1 and 2 (each within the scatter of the next); then compound 3.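

In this assay, the aryl group on the aromatic nitrogen does respond to exchange: methoxy in place of chloro gives a 4.0-fold higher number from compound 2 to compound 3 (0.60 log units; beyond the scatter), whereas no change at the digits printed from compound 1 to compound 2 (within the scatter) had left open whether changes on this group could move the number at all. The 3-methoxyphenyl group also separates from the 4-nitrophenyl group, with a 4.0-fold higher number from compound 1 to compound 3 (0.60 log units; beyond the scatter), so compound 3 is a weaker inhibitor than both earlier compounds, and the two chosen groups on this ring are not interchangeable with methoxy here. Nothing measured here accounts for why this exchange shifts the number when the earlier one did not.

Going by these compounds, it remains open whether the higher number belongs to methoxy alone or extends to other oxygen-linked groups at this place, such as a hydroxy group or a longer ethoxy chain, and whether an amine there would behave like chloro or like methoxy. On these data alone, the two phenyl groups and the methyl and chloro groups on the shared core stay the same in all three compounds, so it is also open whether this step would hold with any of them replaced.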